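The compounds below may be only part of what the source reports. "The series", "measured", "known", "first", "only" and "open" are said of these compounds alone.

Measured in an ADME assay on L6 cells (Rattus norvegicus) for cytotoxicity, read by resazurin assay, with a stated time of 72 h; a higher number here means a weaker inhibitor, a lower number a stronger inhibitor:
- Compound 1 `CN(C)C12CC(c3ccccc3)C(CN(C(=O)CCN3CCCC3)C1)C(c1ccccc1)C2`: 11700 nM
- Compound 2 `CCN(CC)CCC(=O)N1CC2C(c3ccccc3)CC(N(C)C)(CC2c2ccccc2)C1`: 15400 nM
- Compound 3 `CN(C)C12CC(c3ccccc3)C(CN(CCN3CCCCC3)C1)C(c1ccccc1)C2`: 2920 nM

Compound 2 stands at the upper end of these numbers: a 1.3-fold higher number from compound 1 to compound 2 (0.12 log units; within the scatter), and a 5.3-fold lower number from compound 2 to compound 3 (0.72 log units; beyond the scatter). Compound 4 `CN(C)C12CC(c3ccccc3)C(CN(CCCN3CCCCC3)C1)C(c1ccccc1)C2` has not yet been measured. Its change from compound 2 is 3-(piperidin-1-yl)propyl in place of (2-(diethylamino)ethyl)carbonyl on an amine nitrogen in a ring. The closest precedents are the two modest steps to a 2-(piperidin-1-yl)ethyl group, a 5.3-fold lower number from compound 2 to compound 3 (0.72 log units; beyond the scatter) and a 4.0-fold lower number from compound 1 to compound 3 (0.60 log units; beyond the scatter). For the measured compounds named here, no measured step isolates the longer chain, so a similar modest drop in this assay is expected. The estimated step is a 6.2-fold lower number from compound 2 to compound 4 (0.79 log units; beyond the scatter). For compound 4 the estimated value is 2500 nM, with an expected range of 1000 nM to 6000 nM.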

Compound 4, half-maximal inhibitory concentration: 1750 nM
For compound 4 the middle estimate is 1.4-fold (0.15 log units) above the measured one; the range from low to high includes it.
By their numbers in this assay, from the lowest: compounds 4 and 3 (each within the scatter of the next); then compounds 1 and 2 (each within the scatter of the next).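

In this assay, the 3-(piperidin-1-yl)propyl group on the amine nitrogen in a ring stands well below both carbonyl-bearing groups (an 8.8-fold lower number from compound 2 to compound 4 (0.94 log units; beyond the scatter)) and (a 6.7-fold lower number from compound 1 to compound 4 (0.83 log units; beyond the scatter)). For the compounds shown here, the comparison with the 2-(piperidin-1-yl)ethyl group is the first to isolate chain length, and it stays within the scatter (a 1.7-fold lower number from compound 3 to compound 4 (0.22 log units; within the scatter)), so these two chain lengths are not separated here. No measurement offered here explains this result.

Still open, from the compounds shown here alone, is what a 4-(piperidin-1-yl)butyl chain would give at this nitrogen. Also open, going by these compounds, is whether a 3-(diethylamino)propyl group, without the carbonyl but with the diethylamino group kept, would match compound 4.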